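A few compounds are considered here, and "the series" means these few. Any claim that something is new, unique, unknown or untested is made for them only; others in the source may bear on it.

Compounds measured so far in an ADME assay on 184B5 cells (Homo sapiens) for cytotoxicity, read by MTT assay, with a stated time of 72 h; on this read-out lower numbers stand for stronger inhibition of growth and higher numbers for weaker inhibition of growth:

Compound 1 `CCCCC[Se]c1nc(N)c2ccccc2n1` — 43600 nM.
Compound 2 `CSc1nc(NCCCCCO)c2ccccc2n1` — this value is a limit of the assay, > 100000 nM.
Compound 3 `CCCCC[Se]c1nc(NCc2ccccc2)c2ccccc2n1` — this value is also a limit of the assay, > 100000 nM.

Compound 3 thus sits at the limit of > 100000 nM in this assay, at which 2 of the 3 values shown sit. For the measured compounds named here, the one measured step that reaches compound 3, an at least 2.2-fold higher number from compound 1 to compound 3 (0.36 log units; beyond the scatter), is itself only a lower bound. Compound 4 `CSc1nc(NCc2ccccc2)c2ccccc2n1` differs from compound 3 by a group of 2 heavy atoms (1 carbon, 1 sulfur; no ring) in place of a group of 6 heavy atoms (5 carbon, 1 selenium; no ring), on an aromatic carbon. Going by the values given here, no measured step covers this change; compound 2, which also carries methylsulfanyl, gives only a limit. Compound 4 is therefore expected to give no number below the limit, an estimated 100000 nM (range 40000 nM to 300000 nM), so the expected step is a number no higher from compound 3 to compound 4 (the limit leaves the size open).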

Compound 4, concentration for total growth inhibition: > 100000 nM
Compound 4: no number, only a limit; the forecaster's own chance of this, stated with the estimate: 75%; the middle value sits exactly at the limit.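

For the compounds shown here, compound 4 gives only a limit of the assay, as do compound 2 and compound 3, so no step to compound 4 can be read. Going by these compounds, how much methylsulfanyl in place of the larger selenium-bearing group changes growth inhibition stays open.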